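Bornyl ester amines: cytotoxicity on dog kidney cells

The source may hold more compounds than are shown below. What is called first, only, known or untested is meant among the compounds shown, and "the series" means these compounds.

Measured compounds:
compound 1, `CC1(C)[C@H]2CC[C@]1(C)[C@H](OC(=O)CCN1CCNCC1)C2` — 12600 nM
compound 2, `CCOC(=O)N1CCN(CCC(=O)O[C@@H]2C[C@@H]3CC[C@@]2(C)C3(C)C)CC1` — 150000 nM
compound 3, `CCCCN(CCCC)CCC(=O)O[C@@H]1C[C@@H]2CC[C@@]1(C)C2(C)C` — 41800 nM

In an ADME assay on MDCK cells (Canis lupus familiaris) for cytotoxicity, read by MTT assay, with a stated time of 48 h (a lower number here means that less compound is tolerated, a higher number that more compound is tolerated), compound 1 gives the lowest of the three numbers; compound 3 stands nearer to it and compound 2 furthest from it, both with differences beyond the scatter. Within the data shown here, the one counted step within the measured set, a 12-fold higher number from compound 1 to compound 2 (1.08 log units; beyond the scatter), is large and goes upward; it concerns the amine nitrogen in the ring, not the ring itself.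

The new compound 4, `CC1(C)[C@H]2CC[C@]1(C)[C@H](OC(=O)CCN1CCCC1)C2`, differs from compound 1 by pyrrolidin-1-yl in place of piperazin-1-yl on a saturated chain carbon, two bonds along the chain from a carbonyl carbon. Among the measured compounds shown here, no measured step shows this exact change, so the step from compound 1 to compound 2 bears on it only loosely: both changes touch the terminal amine of the chain, and the two measured comparators that lack the free ring amine of compound 1 both sit higher in this assay. A moderate upward step is therefore expected for compound 4, a 2.4-fold higher number from compound 1 to compound 4 (0.38 log units; beyond the scatter), smaller than the capping step and uncertain. Compound 4 is estimated at 30000 nM, within 12000 nM to 80000 nM.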

Compound 4, half-maximal cytotoxic concentration: 125000 nM
Beside the measured number, compound 4's estimate is 4.2-fold (0.62 log units) below it, and the stated range ends below it.
By their numbers in this assay, from the lowest: compound 1; then compound 3; then compounds 4 and 2 (each within the scatter of the next).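

In this assay, pyrrolidin-1-yl in place of piperazin-1-yl on a saturated chain carbon, two bonds along the chain from a carbonyl carbon, gives a 9.9-fold higher number from compound 1 to compound 4 (1.00 log units; beyond the scatter). The earlier step, a 12-fold higher number from compound 1 to compound 2 (1.08 log units; beyond the scatter), kept the piperazine ring and capped its amine nitrogen with ethoxycarbonyl; this result shows that an upward step beyond the scatter also comes with exchanging the whole ring, so that the free ring amine of compound 1 is gone in both changes. No measurement on hand explains this step.

The two steps do not separate the change in ring size from the loss of the second ring nitrogen. As far as these compounds go, a piperidin-1-yl or morpholin-4-yl group at the same place would bear on that, and the effect of a longer chain to the ring remains open.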